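The source may hold more compounds than are shown below. What is called first, only, known or untested is meant among the compounds shown, and "the series" means these compounds.

Compound 1 `COc1ccc(-c2cc3c(OC)ccc(OC)c3nc2O)cc1`: 10000 nM
Compound 2 `COc1cc(OC)c2cc(-c3ccc(OCc4ccccc4)cc3)c(O)nc2c1`: 10000 nM
Compound 3 `COc1ccc(-c2cc3c(OC)cc(OC)cc3n(C)c2=O)cc1`: 10000 nM

All three compounds were tested in a functional assay on J82 cells (Homo sapiens) for cytotoxicity, read by colorimetric assay and MTT assay; a higher number here means a weaker inhibitor, a lower number a stronger inhibitor. Compound 3 stands level with compound 1 and compound 2 at the digits shown: the gap to compound 1 is the smaller one and the gap to compound 2 the larger one, yet neither reaches beyond the scatter of repeated measurements, so none of the three can be set apart from the others on these numbers.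

Compound 4 `COc1ccc(-c2cc3c(OC)cc(OC)cc3n(CCC#N)c2=O)cc1` differs from compound 3 in one place: cyanomethyl in place of hydrogen on a saturated chain carbon bound to an aromatic nitrogen. A cyanomethyl group now sits where compound 3 carries a hydrogen.

Within the data shown here, no step between measured compounds is available as a yardstick. What the numbers do show is that compound 1, compound 2 and compound 3, which differ from one another in several places, all give the same reading in this assay. On that basis the expected step is no change at the digits printed from compound 3 to compound 4 (within the scatter), none beyond the scatter. Compound 4 is therefore expected to give about 10000 nM, within a range of 5000 nM to 10000 nM.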

Compound 4, half-maximal inhibitory concentration: 10000 nM
Compound 4: the middle estimate sits on the measured number at the digits printed, and the stated range covers the measured number.
By their numbers in this assay, from the lowest: compounds 1, 2, 3 and 4 (each within the scatter of the next).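

In this assay, among these compounds, the reading shows no change at the digits printed from compound 3 to compound 4 (within the scatter) and this is the first comparison in the set between two compounds that differ in one place. It shows that cyanomethyl in place of hydrogen on a saturated chain carbon bound to an aromatic nitrogen, which can also be read as methyl to 2-cyanoethyl, leaves the reading unmoved. Nothing available explains why the reading stays the same.

From the compounds shown here alone, whether another group at this place, such as an amine, a carboxylic acid or a longer chain, would shift the reading remains open. All the compounds shown give the same reading, so it also remains open whether any change at this place can separate one compound from another in this assay.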